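Triazolylthio benzyl series: cytotoxicity notes on compound 4

The source may hold more compounds than are shown below. What is called first, only, known or untested is meant among the compounds shown, and "the series" means these compounds.

Measured in an ADME assay on A-431 cells (Homo sapiens) for cytotoxicity, with a stated time of 48 h; on this read-out lower numbers stand for stronger inhibition and higher numbers for weaker inhibition:
- compound 1 `O=[N+]([O-])c1cc(CSc2nnc(-c3ccccc3)n2C2CCCCC2)cc([N+](=O)[O-])c1` gives > 30000 nM, a limit of the assay.
- compound 2 `O=[N+]([O-])c1cc(CSc2nnc(-c3ccc(Cl)cc3)n2Cc2ccccc2)cc(C(F)(F)F)c1` gives > 30000 nM, also only a limit.
- compound 3 `COc1ccc(CSc2nnc(-c3cc([N+](=O)[O-])cc([N+](=O)[O-])c3)n2C)cc1` gives > 30000 nM, again a limit rather than a number.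

Compound 3 therefore stands nowhere distinguishable within this assay: every value shown is a limit, as summed up by the limit of > 30000 nM in this assay, at which 3 of the 3 values shown sit. Compound 4 `Cn1c(SCc2ccc(Cl)c(Cl)c2)nnc1-c1cc([N+](=O)[O-])cc([N+](=O)[O-])c1` differs from compound 3 by 3,4-dichlorophenyl in place of 4-methoxyphenyl on a saturated chain carbon bound to a sulfur. Among the compounds with values here, no step between two measured compounds is available, so nothing in the data points to a change beyond the scatter in either direction. Compound 4 is therefore expected to remain at the limit, with an estimated 40000 nM (range 15000 nM to 120000 nM), an expected step that the limit leaves unreadable from compound 3 to compound 4.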

Compound 4, half-maximal inhibitory concentration: > 30000 nM
Compound 4: only a limit was reported (the forecaster's own chance of this, stated with the estimate: 85%); the middle value does not contradict the limit.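

Compound 3 and compound 4 both give only a limit, so no step between them can be read: the limit of > 30000 nM in this assay, at which 4 of the 4 values shown sit.

Whether 3,4-dichlorophenyl in place of 4-methoxyphenyl changes the read-out at all stays open, since the compounds shown offer no numerical value.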